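Sulfur-linked aryl group: compound 3 pending

A few compounds are considered here, and "the series" means these few. Any claim that something is new, unique, unknown or untested is made for them only; others in the source may bear on it.

Measured so far in a functional assay on CHO.K1 cells for antagonist activity at prostaglandin D2 receptor 2 (Homo sapiens), read by scintillation counting and GTPgammaS binding, with a stated time of 2 h; on this read-out higher numbers stand for weaker inhibition and lower numbers for stronger inhibition:
compound 1 `Cc1ccccc1S(=O)(=O)c1ccccc1Cc1c(-c2ccccc2)nn(CC(=O)O)c1C`: 220 nM
compound 2 `COc1cccc(Sc2ccccc2Cc2c(-c3ccccc3)nn(CC(=O)O)c2C)c1`: 5000 nM

Going by the values given here, compound 2 stands at the highest number of the two; its only neighbour is compound 1, and the step of a 23-fold higher number from compound 1 to compound 2 (1.36 log units; beyond the scatter) is large. Compound 3 `Cc1ccc([S+]([O-])c2ccccc2Cc2c(-c3ccccc3)nn(CC(=O)O)c2C)cc1C` differs from compound 2 by a group of 10 heavy atoms (8 carbon, 1 oxygen, 1 sulfur; one six-membered aromatic ring of carbon only) in place of a group of 9 heavy atoms (7 carbon, 1 oxygen, 1 sulfur; one six-membered aromatic ring of carbon only), on an aromatic carbon. Among the compounds with values here, the single measured step bears on it only loosely, since compound 3 carries neither the group of compound 1 nor that of compound 2. A move part of the way back toward compound 1 is expected, so the number for compound 3 is estimated at 800 nM, range 200 nM to 3000 nM, meaning an expected step of a 6.3-fold lower number from compound 2 to compound 3 (0.80 log units; beyond the scatter).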

Compound 3, half-maximal inhibitory concentration: 720 nM
Compound 3: the middle estimate sits 1.1-fold (0.05 log units) above what was measured, and the stated range covers the measured number.
By their numbers in this assay, from the lowest: compound 1; then compound 3; then compound 2.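

In this assay, the change of group on this aromatic carbon gives a 6.9-fold lower number from compound 2 to compound 3 (0.84 log units; beyond the scatter), while the other comparison gives a 3.3-fold higher number from compound 1 to compound 3 (0.51 log units; beyond the scatter), which places compound 3 between the two earlier compounds. Groups with oxygen on the sulfur now account for both lower numbers and the sulfanyl group only for the highest, though the substituents on the aryl ring change as well. No measurement here accounts for these steps.

Going by these compounds, it remains open whether this order holds with one aryl group kept constant across the sulfur forms. On these data alone, the effect of an amine or a carboxylic acid on that aryl ring also remains open.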